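Imine series: nitro removed from the aromatic ring

The source may hold more compounds than are shown below. What is called first, only, known or untested is meant among the compounds shown, and "the series" means these compounds.

Three imines have been measured in a functional assay on the whole organism (strain Swiss albino) with Mus musculus as the target, in the maximal electroshock model, with a stated time of 0.5 h; a higher number here means that more compound is needed for the effect, a lower number that less compound is needed. Compound 1 `COc1cc(/C=N/Cc2cccnc2)ccc1O` gives 100 mg/kg, compound 2 `O=[N+]([O-])c1ccc(/C=N/Cc2cccnc2)cc1` gives 100 mg/kg, and compound 3 `C(=N/Cc1cccnc1)\c1c[nH]c2ccccc12` gives 300 mg/kg. Compound 2 stands level with compound 1 at the digits recorded, the two together at the lowest number of the three; its nearest neighbour is compound 1, with no change within the scatter, and its furthest is compound 3, whose higher number lies beyond the scatter. Compound 4 `C(=N/Cc1cccnc1)\c1ccccc1` is still to be measured. It differs from compound 2 thus: hydrogen in place of nitro on an aromatic carbon. Among the measured compounds shown here, no measured pair shows the effect of this change, so the expectation rests on compound 2 alone. A small rise in the number is expected, estimated as a 1.5-fold higher number from compound 2 to compound 4 (0.18 log units; within the scatter). Compound 4 is expected to give 150 mg/kg, within 60 mg/kg to 400 mg/kg.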

Compound 4, minimum effective dose: 100 mg/kg
Compound 4: the middle estimate sits 1.5-fold (0.18 log units) above what was measured; low and high end bracket the measured number.
By their numbers in this assay, from the lowest: compounds 1, 2 and 4 (each within the scatter of the next); then compound 3.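

Hydrogen in place of nitro on the aromatic carbon gives no change at the digits printed from compound 2 to compound 4 (within the scatter) in this assay and is the first single-place step in the series. At this position, para to a group of 9 heavy atoms, nitro is therefore not required to hold the dose at this level. No available data bear on why the dose holds.

From the compounds shown here alone, it remains open whether an amine or a carboxylic acid at this position would shift the dose. This single pair also leaves open whether the same exchange would give the same result on another core.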